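The compounds below may be only part of what the source reports. "The series", "measured", "known", "first", "only" and "open" are said of these compounds alone.

Of the compounds shown here, two have been measured in an ADME assay on Huh-7 cells (Homo sapiens) for cytotoxicity, read by MTT assay, with a stated time of 72 h; a higher number here means that more compound is tolerated, a lower number that less compound is tolerated. Compound 1 `CN(O)C(=O)c1ccccc1O` returns only a limit there, giving > 800000 nM. Compound 2 `CONC(=O)c1ccccc1` likewise returns a limit, > 800000 nM. Compound 2 thus stands together with compound 1 at the ceiling of what the data show, with nothing separating the two since both sit at the limit of > 800000 nM in this assay, at which 2 of the 2 values shown sit. Going by the values given here, no step between measured compounds has been worked out. Compound 3 `CONC(=O)c1ccccc1O` is the next member: it differs from compound 2 by hydroxy in place of hydrogen on an aromatic carbon, a hydroxy in place of hydrogen on an aromatic carbon. The same hydroxy is already carried by compound 1, whose tolerance in this assay is a limit as well. The step expected in this assay is a number no higher from compound 2 to compound 3 (the limit leaves the size open), none beyond the usual scatter. For compound 3 the estimate in this assay is 800000 nM, within 400000 nM to 1600000 nM, and most probably reported again only as a limit.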

Compound 3, half-maximal cytotoxic concentration: > 800000 nM
Compound 3 ended at the assay's limit (the forecaster's own chance of this, stated with the estimate: 85%); the middle value sits exactly at the limit.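

No new step can be read among compound 1, compound 2 and compound 3 in this assay, because each returns only a limit: the limit of > 800000 nM in this assay, at which 3 of the 3 values shown sit.

The compounds shown leave open the concentration at which any of the three becomes cytotoxic, and whether either change alters tolerance at all.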